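Varying the aryl group at the triazole carbon: compound 4

The source may hold more compounds than are shown below. What is called first, only, known or untested is meant among the compounds shown, and "the series" means these compounds.

Compound 1 `O=C(NO)c1ccc(NCc2nc(-c3cccnc3)nn2-c2ccccc2)cc1`: 57.7%
Compound 2 `Cc1ccccc1-c1nc(CNc2ccc(C(=O)NO)cc2)n(-c2ccccc2)n1`: 53.2%
Compound 3 `O=C(NO)c1ccc(NCc2nc(-c3ccco3)nn2-c2ccccc2)cc1`: 59.9%

In an assay on Sf9 cells for inhibition of protein deacetylase HDAC6 (Homo sapiens), read by fluorescence, with a stated time of 40 min, tested at 100 nM (a higher number here means more inhibition at the concentration tested (going by the name of the read-out), a lower number less inhibition), the three measured compounds differ only in the aryl group on the aromatic carbon between two ring nitrogen atoms, and all three numbers lie within the scatter of one another; compound 3 sits at the upper end of that spread, with a number 2.2 percentage points higher from compound 1 to compound 3 (within the scatter) and a number 6.7 percentage points higher from compound 2 to compound 3 (within the scatter), while a number 4.5 percentage points lower from compound 1 to compound 2 (within the scatter). Compound 4 `O=C(NO)c1ccc(NCc2nc(-c3ccccn3)nn2-c2ccccc2)cc1` changes the same position: pyridin-2-yl in place of furan-2-yl on an aromatic carbon. Since every exchange of this group so far stayed within the scatter, no step beyond the scatter is expected in this assay, and a number 2.9 percentage points lower from compound 3 to compound 4 (within the scatter) is the estimated change. Compound 4 is therefore expected to give about 57%, within 47% to 67%.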

Compound 4, a percentage reported as inhibition, at one concentration (the size of the read-out at that concentration, not a potency): 58.6%
Compound 4: the middle estimate sits 1.6 percentage points below what was measured, and the stated range covers the measured number.
By their numbers in this assay, from the lowest: compounds 2, 1, 4 and 3 (each within the scatter of the next).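

In this assay, pyridin-2-yl on this aromatic carbon extends the series to a six-membered ring with its hetero atom placed differently, and all three comparisons stay within the scatter: a number 1.3 percentage points lower from compound 3 to compound 4 (within the scatter), a number 5.4 percentage points higher from compound 2 to compound 4 (within the scatter) and a number 0.9 percentage points higher from compound 1 to compound 4 (within the scatter). The last step shows that exchanging pyridin-3-yl for pyridin-2-yl gives no change beyond the scatter. Nothing available explains these numbers.

The compounds shown leave open whether an amine, a carboxylic acid or a longer alkyl chain on this carbon would keep the number within the same scatter. They also leave open what replacing the phenyl group would do.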